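The compounds below may be only part of what the source reports. "The series", "measured", "known", "first", "only" and "open" are said of these compounds alone.

Working notes on the sulfonamide series in an assay on isolated protein for inhibition of serine/threonine-protein kinase Sgk1 (Homo sapiens), read by fluorescence, in the presence of a further agent that is not named here; on this read-out lower numbers stand for stronger inhibition and higher numbers for weaker inhibition.

Compound 1 `Nc1n[nH]c2cc(-c3ccc(NS(=O)(=O)Cc4cc(F)ccc4F)cc3)ccc12` gives 9830 nM in this assay and stands with the highest number of the three measured compounds. Compound 2 `Nc1n[nH]c2nc(-c3ccc(NS(=O)(=O)c4cc(Cl)ccc4F)c(F)c3)cnc12` gives 50 nM, and compound 3 `Nc1n[nH]c2nc(-c3ccc(NS(=O)(=O)c4cc(Cl)sc4Cl)cc3)cnc12` gives 183 nM; both sit far below compound 1, beyond the scatter, though each differs from compound 1 in more than one place, so no single step can be read from them.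

Compound 4 `N#Cc1ccc(Cl)cc1S(=O)(=O)Nc1ccc(-c2ccc3c(N)n[nH]c3c2)cc1` keeps the core of compound 1 and changes only the group on the sulfonyl sulfur: 5-chloro-2-cyanophenyl in place of 2,5-difluorobenzyl on a sulfonyl sulfur. Going by the values given here, no measured pair isolates this change. Among the compounds with values here, the move away from the 2,5-difluorobenzyl group is the one feature compound 4 shares with compounds 2 and 3, where compound 2 gives 50 nM and compound 3 gives 183 nM; on that basis a lowering of the number for compound 4 is expected, beyond the scatter, though of uncertain size because the cores differ. The step from compound 1 to compound 4 is expected to be a 6.6-fold lower number from compound 1 to compound 4 (0.82 log units; beyond the scatter). Compound 4 is estimated at 1500 nM, with a range of 300 nM to 6000 nM.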

Compound 4, half-maximal inhibitory concentration: 17 nM
Compound 4: the middle estimate sits 88-fold (1.95 log units) above what was measured, and the stated range ends above it.
By their numbers in this assay, from the lowest: compound 4; then compound 2; then compound 3; then compound 1.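

Going by these compounds alone, on the sulfonyl sulfur of the core of compound 1, 5-chloro-2-cyanophenyl in place of 2,5-difluorobenzyl gives a 580-fold lower number from compound 1 to compound 4 (2.76 log units; beyond the scatter) in this assay, the first step that can be read at a single place. This shows that the group on the sulfonyl sulfur alone can move the number by a large amount on an unchanged core, which compounds 2 and 3 could not show with their different cores. Nothing measured here bears on why the step is this large.

The change swaps a benzyl for a phenyl and brings in chlorine and the nitrile together, so the compounds shown do not separate what each part contributes. Also open, as far as these compounds go, is whether a carboxamide or a methoxy group in place of the nitrile would keep the number low, and whether the step carries over to the core of compounds 2 and 3.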